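The compounds below may be only part of what the source reports. "The series", "measured", "known", "first", "only" and "open" are said of these compounds alone.

Measured in an ADME assay on the whole organism (plasma) for metabolic stability, with Rattus norvegicus as the target; a higher number here means that the compound lasts longer, a lower number that the compound disappears faster:
Compound 1 `COC(=O)CCCC=C(c1cc(Cl)c(OC)c(C(=O)OC)c1)c1cc(Cl)c(OC)c(C(=O)OC)c1` gives 0.0967 h
Compound 2 `COC(=O)c1cc(C(=CCCCc2ccccc2)c2cc(Br)c(OC)c(C(=O)OC)c2)cc(Br)c1OC` gives 0.917 h

Compound 1 has the lower of the two numbers, and the gap up to compound 2 lies beyond the scatter. Compound 3 `COC(=O)c1cc(C(=CCCCc2ccccc2)c2cc(Cl)c(OC)c(C(=O)OC)c2)cc(Cl)c1OC` has not yet been measured. It departs from compound 1 in one place: phenyl in place of methoxycarbonyl on a saturated chain carbon, three bonds along the chain from a double-bonded chain carbon. In short, 3-(methoxycarbonyl)propyl becomes 3-phenylpropyl. Within the data shown here, no one-place step between measured compounds is available to size this change. Among the measured compounds shown here, the only guide is compound 2, which also carries 3-phenylpropyl and gives 0.917 h. A rise beyond the scatter in this assay is therefore expected, somewhat smaller than that gap. The expected change is a 7.2-fold higher number from compound 1 to compound 3 (0.86 log units; beyond the scatter). For compound 3 the estimate is 0.7 h, with an expected range from 0.3 h to 1.5 h.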

Compound 3, half-life: 1.28 h
The estimate for compound 3 lay 1.8-fold (0.26 log units) below the measured number, and the stated range covers the measured number.
By their numbers in this assay, from the lowest: compound 1; then compounds 2 and 3 (each within the scatter of the next).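

With the rest of the core of compound 1 held fixed, replacing 3-(methoxycarbonyl)propyl with 3-phenylpropyl gives a 13-fold higher number from compound 1 to compound 3 (1.12 log units; beyond the scatter) in this assay. Among these compounds, the earlier gap between compound 1 and compound 2 came with a second difference, the halogen on the aromatic rings, so this step is the first to size the change at the chain end on its own. It shows that this one place, on a saturated chain carbon, three bonds along the chain from a double-bonded chain carbon, can by itself move the number by a large step.

The compounds shown leave open whether the phenyl ring is needed or whether another end group, such as cyclohexyl, a carboxylic acid or an amide, would do the same, and how a shorter or longer chain would behave. What lies behind the step also stays open, as no measurement here speaks to it.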